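This account rests on a few compounds, and the source may have more. Where it says the series, first, only, none or still open, it means among the compounds named here.

Measured compounds:

compound 1 `COc1cc(C(C)=O)ccc1OCCCN1CCC(Cc2ccc(F)cc2)CC1` gives 20 nM in a functional assay (aorta) with Oryctolagus cuniculus as the target; a lower number here means tighter binding, a higher number weaker binding
compound 2 `COc1cc(C(C)=O)ccc1OCCCN1CCC(C(NC(C)=O)(c2ccc(F)cc2)c2ccc(F)cc2)CC1` gives 63.1 nM
compound 3 `CC(=O)c1ccc(OCCCN2CCC(C(c3ccc(F)cc3)c3ccc(F)cc3)CC2)cc1` gives 2.51 nM

Of the three measured compounds, compound 3 has the lowest number in this assay, and its distances to compound 1 and to compound 2 both lie beyond the usual scatter, so it stands as the tightest binder among them. Compound 4 `Fc1ccc(C(c2ccc(F)cc2)C2CCN(CCCOc3ccc4ccccc4c3)CC2)cc1` has not yet been measured. Its structure is that of compound 3 with one change: naphthalen-2-yl in place of 4-acetylphenyl on an oxygen on a saturated carbon. The change removes the one hydrogen-bond acceptor that was counted in the group that leaves, and the entering group is larger by one heavy atom. For the measured compounds named here, no measured pair in this set shows what such a change does, so the size of the step can only be guessed. The author expects compound 4 to give a number somewhat higher than that of compound 3, a step of a 2.4-fold higher number from compound 3 to compound 4 (0.38 log units; beyond the scatter), though it could also fall within the scatter of repeated measurement. Compound 4 is therefore estimated at 6 nM, with a range from 1.5 nM to 25 nM.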

Compound 4, dissociation constant: 7.94 nM
For compound 4 the middle estimate is 1.3-fold (0.12 log units) below the measured one; the range from low to high includes it.
By their numbers in this assay, from the lowest: compound 3; then compound 4; then compound 1; then compound 2.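

In this assay, for the compounds shown here, the only step read so far at this place, on an oxygen on a saturated carbon, putting naphthalen-2-yl in place of 4-acetylphenyl gives a 3.2-fold higher number from compound 3 to compound 4 (0.50 log units; beyond the scatter). The step is modest but beyond the scatter, and compound 4 still gives 7.94 nM, so a group with no hydrogen-bond acceptor and two six-membered aromatic rings can stand here and keep a value of that order. Nothing measured here speaks to the reason for this step.

The step joins two differences, the loss of the acetyl group and the gain of a second aromatic ring, and the compounds shown do not separate them. A plain phenyl on the same oxygen would isolate the acetyl group's share, and a quinoline would show what a ring nitrogen does in the naphthalene's place.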